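One Limit and an Open Step to Compound 3

The source may hold more compounds than are shown below. What is called first, only, known or untested is meant among the compounds shown, and "the series" means these compounds.

Compound 1 `CC1=C(CN2CC(C(=O)O)C2)CCc2cc(OCC3CCc4ccccc4C3)ccc21`: "not determined" (no result reported)
Compound 2 `CC1=C(CN2CC(C(=O)O)C2)CCc2cc(OCC3Cc4ccccc4C3)ccc21`: > 1 mg/kg

In a functional assay on the whole organism (strain BALB/c) with Mus musculus as the target, with a stated time of 4 h (a lower number here means that less compound is needed, a higher number that more compound is needed for the effect), compound 2 gives > 1 mg/kg, which is a limit of the assay and not a number. Among the compounds with values here, compound 1 has no result, so no measured pair exists to show how a change in this part of the molecule plays out. Compound 3 (`CC1=C(CN2CC(C(=O)O)C2)CCc2cc(OCCC3CCc4ccccc43)ccc21`) keeps the shared core. On a saturated chain carbon bound to an oxygen on an aromatic ring, (2,3-dihydro-1H-inden-1-yl)methyl takes the place of 2,3-dihydro-1H-inden-2-yl ((2,3-dihydro-1H-inden-1-yl)methyl in place of 2,3-dihydro-1H-inden-2-yl on a saturated chain carbon bound to an oxygen on an aromatic ring). Within the data shown here, with no measured step to size this change, no shift beyond the usual scatter is expected, and no direction can be favoured. The expected step is small (a step that the limit leaves unreadable from compound 2 to compound 3). The dose for half-maximal effect of compound 3 is estimated at 1.5 mg/kg (range 0.3 mg/kg to 5 mg/kg), and the assay may again report only a limit.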

Compound 3, dose for half-maximal effect: > 1 mg/kg
Compound 3 gave a limit, no number; the forecaster's own chance of this, stated with the estimate: 50%; the middle value does not contradict the limit.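

In this assay, within the data shown here, compound 2 and compound 3 each give only a limit of the assay and not a number, so no step between them can be read. The compounds shown leave open whether (2,3-dihydro-1H-inden-1-yl)methyl in place of 2,3-dihydro-1H-inden-2-yl shifts the dose for half-maximal effect at all.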